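The source may report more compounds than this note shows. Statements on the series, on what has been measured and on what is new or still open speak of the compounds shown alone.

Of the compounds shown here, two have been measured in a functional assay on MCF7 cells (Homo sapiens) for cytotoxicity, read by MTT assay, with a stated time of 72 h; on this read-out higher numbers stand for weaker inhibition and lower numbers for stronger inhibition. Compound 1 `CN1[C@@H]2c3[nH]c4ccccc4c3C[C@H]1[C@H](C#N)N1[C@@H](CNC(=O)c3cccc(C(F)(F)F)c3)c3[nH]c4ccccc4c3C[C@@H]21` gives 110 nM in this assay. Going by the values given here, compound 2 `COc1ccc(C(=O)NC[C@H]2c3[nH]c4ccccc4c3C[C@H]3[C@H]4c5[nH]c6ccccc6c5C[C@@H]([C@H](C#N)N23)N4C)cc1` gives 600 nM, and the only step available, a 5.5-fold higher number from compound 1 to compound 2 (0.74 log units; beyond the scatter), covers the aryl group on the carbonyl carbon of the amide. Compound 2 thus stands with the highest of the two numbers, compound 1 sitting below it by that step.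

Compound 3 `CN1[C@@H]2c3[nH]c4ccccc4c3C[C@H]1[C@H](C#N)N1[C@@H](CNC(=O)c3ccc4ccccc4n3)c3[nH]c4ccccc4c3C[C@@H]21` differs from compound 2 at the same place: quinolin-2-yl in place of 4-methoxyphenyl on a carbonyl carbon. Among the compounds with values here, the single step of a 5.5-fold higher number from compound 1 to compound 2 (0.74 log units; beyond the scatter) shows that the aryl group on the carbonyl carbon can move this assay by a modest amount, but with only one such step there is no basis for a direction. A step of similar size is expected, more likely toward a lower number than a higher one, so compound 3 is estimated at 250 nM (range 60 nM to 1200 nM), which would be expected to mean a 2.4-fold lower number from compound 2 to compound 3 (0.38 log units; beyond the scatter).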

Compound 3, half-maximal inhibitory concentration: 150 nM
Beside the measured number, compound 3's estimate is 1.7-fold (0.22 log units) above it, within the range that was stated.
By their numbers in this assay, from the lowest: compounds 1 and 3 (each within the scatter of the next); then compound 2.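

In this assay, the group on the carbonyl carbon gives a second step beyond the scatter: quinolin-2-yl in place of 4-methoxyphenyl brings a 4.0-fold lower number from compound 2 to compound 3 (0.60 log units; beyond the scatter) in this series. Quinolin-2-yl in place of 3-(trifluoromethyl)phenyl gives only a 1.4-fold higher number from compound 1 to compound 3 (0.13 log units; within the scatter) and so is not separated from it on this read-out, showing that two different aromatic groups can give values within the scatter of each other while 4-methoxyphenyl stands apart from both. Nothing available accounts for these steps.

On these data alone, whether an aromatic group is needed on the carbonyl carbon remains open, and a cyclohexyl or methyl group there would address this. A pyridin-2-yl group would show whether the second ring of quinolin-2-yl contributes to the value.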